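The source may report more compounds than this note shows. Statements on the series, on what has been measured and on what is new or still open speak of the compounds shown alone.

Compound 1 `CC1(c2ccccc2)CC(=O)N(CC(=O)N2CCN(c3ccccc3F)CC2)C1=O`, compound 2 `CC1(c2ccccc2)CC(=O)N(CC(=O)N2CCN(c3cccc(Cl)c3)CC2)C1=O` and compound 3 `COc1cccc(N2CCN(C(=O)CN3C(=O)CC(C)(c4ccccc4)C3=O)CC2)c1` share one core and differ only in the aryl group on the amine nitrogen in the ring. In a functional assay on the whole organism (strain CD-1) with Mus musculus as the target, with a stated time of 0.5 h (on this read-out lower numbers stand for an effect already at smaller amounts and higher numbers for an effect only at larger amounts of compound), compound 1 gives 100 mg/kg. Compound 2 is reported in this assay as "not active" (no number reported), without a number. Compound 3 gives 100 mg/kg in this assay and stands level with compound 1; the step of no change at the digits printed from compound 1 to compound 3 (within the scatter) lies within the scatter. Compound 4 `CC1(c2ccccc2)CC(=O)N(CC(=O)N2CCN(c3ccccc3)CC2)C1=O` is to be measured next. The change from compound 3 is hydrogen in place of methoxy on an aromatic carbon. Among the measured compounds shown here, the only measured step, an exchange of one aryl substituent for another, moved nothing beyond the scatter, and no measured step removes a substituent entirely, so no shift beyond the scatter is expected. The step expected is no change at the digits printed from compound 3 to compound 4 (within the scatter). Compound 4 is expected near 100 mg/kg, ranging from 50 mg/kg to 200 mg/kg.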

Compound 4, minimum effective dose: 100 mg/kg
Compound 4: middle estimate and measured number agree at the digits printed; the range from low to high includes it.
By their numbers in this assay, from the lowest: compounds 1, 3 and 4 (each within the scatter of the next).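

In this assay, removing the substituent altogether gives no change at the digits printed from compound 3 to compound 4 (within the scatter), and the same holds for the fluoro group, with no change at the digits printed from compound 1 to compound 4 (within the scatter). The bare phenyl thus stands level with both substituted rings, so neither methoxy nor fluoro is needed for this read-out. Nothing at hand bears on why this is so.

As far as these compounds go, compound 2, with its chloro group, remains without a number, and what separates it from compound 4 stays open. An amine or a carboxylic acid on this aromatic ring also remains untested in the compounds shown.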